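Fluorophenyl series: from compound 2 to compound 3

This account rests on a few compounds, and the source may have more. Where it says the series, first, only, none or still open, it means among the compounds named here.

Measured in a functional assay on LNCaP cells (Homo sapiens) for cytotoxicity, read by MTT assay, with a stated time of 72 h; a lower number here means a stronger inhibitor, a higher number a weaker inhibitor:
- compound 1 `CC1=C(/C=C/C(=O)/C=C/c2ccccc2)C(C)(C)CCC1O`: 5800 nM
- compound 2 `CC1=C(/C=C/C(=O)/C=C/c2ccccc2F)C(C)(C)CCC1O`: 2900 nM

Within the data shown here, compound 2 stands within the scatter of compound 1, the only other compound measured so far. The next compound, compound 3 `CC1=C(/C=C/C(=O)/C=C/c2ccc(F)cc2)C(C)(C)CCC1O`, differs from compound 2 as follows: 4-fluorophenyl in place of 2-fluorophenyl on a double-bonded chain carbon bound to a double-bonded chain carbon. The fluoro group therefore appears in 4-fluorophenyl in place of 2-fluorophenyl, on a double-bonded chain carbon bound to a double-bonded chain carbon. Among the measured compounds shown here, only one measured step bears on this change: a 2.0-fold lower number from compound 1 to compound 2 (0.30 log units; within the scatter). For the measured compounds named here, no measured compound yet carries 4-fluorophenyl, so the data give no direct reading of it. Going by the values given here, with only that step to go on, no change beyond the scatter is expected in this assay. The expected step is a 1.2-fold higher number from compound 2 to compound 3 (0.08 log units; within the scatter). The estimate for compound 3 is 3500 nM, with an expected range of 1500 nM to 8000 nM.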

Compound 3, half-maximal inhibitory concentration: 3900 nM
Beside the measured number, compound 3's estimate is 1.1-fold (0.05 log units) below it; low and high end bracket the measured number.
By their numbers in this assay, from the lowest: compounds 2, 3 and 1 (each within the scatter of the next).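

Moving the fluoro group, with 4-fluorophenyl in place of 2-fluorophenyl on a double-bonded chain carbon bound to a double-bonded chain carbon, gives a 1.3-fold higher number from compound 2 to compound 3 (0.13 log units; within the scatter) in this assay, so the two fluorophenyl isomers cannot be told apart in this assay. Fluoro in place of hydrogen at the new ring position gives a 1.5-fold lower number from compound 1 to compound 3 (0.17 log units; within the scatter), so neither fluorophenyl compound yet separates from the phenyl parent, compound 1, and a single fluoro group on this ring has so far produced no step beyond the scatter. No measurement here offers a reason for these small differences.

On these data alone, whether a larger or more strongly different ring substituent, such as trifluoromethyl, methoxy or an amine, would give a step beyond the scatter remains open. So does whether a carboxylic acid at this ring would be read any differently from fluoro.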